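Working notes: butyl in place of the ring on the aromatic nitrogen

A few compounds are considered here, and "the series" means these few. Any claim that something is new, unique, unknown or untested is made for them only; others in the source may bear on it.

Compound 1 `C=CCn1c(=O)n(C2C=CC(CO)O2)c2nc(N)nc(O)c21`: 30 uM
Compound 2 `CCCn1c(=O)n(C2C=CC(CO)O2)c2nc(N)nc(O)c21`: 52 uM
Compound 3 `Cn1c(=O)n(C2OC(CO)[C@@H](O)[C@H]2O)c2nc(N)nc(O)c21`: 120 uM

All numbers come from a functional assay with Mus musculus as the target; a higher number here means that more compound is needed for the effect, a lower number that less compound is needed. Compound 1 gives 30 uM, the low end of the three numbers shown. The nearest is compound 2 at 52 uM; the step of a 1.7-fold higher number from compound 1 to compound 2 (0.24 log units; within the scatter) stays within the scatter, so the two cannot be ordered. The furthest is compound 3 at 120 uM, beyond the scatter from compound 1; compound 3 differs from compound 1 in two places, so these two values alone say nothing about either change on its own.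

Compound 4 `C=CCn1c(=O)n(CCCC)c2nc(N)nc(O)c21` has not yet been measured in this assay. Relative to compound 1 the change is a group of 4 heavy atoms (4 carbon; no ring) in place of a group of 7 heavy atoms (5 carbon, 2 oxygen; one five-membered non-aromatic ring with 1 hetero atom), on an aromatic nitrogen. Within the data shown here, no measured step bears on this change: the only measured step, a 1.7-fold higher number from compound 1 to compound 2 (0.24 log units; within the scatter), alters the chain on the other ring nitrogen and keeps the five-membered non-aromatic ring in place. Among the measured compounds shown here, the expectation for compound 4 therefore rests on no direct precedent and is wide. The estimated step of a 2.7-fold higher number from compound 1 to compound 4 (0.43 log units; beyond the scatter) is a higher number, probably beyond the scatter, with the direction itself uncertain. For compound 4 in this assay the estimate is 80 uM, with a range from 25 uM to 300 uM.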

Compound 4, concentration for half-maximal effect: 11 uM
The estimate for compound 4 lay 7.3-fold (0.86 log units) above the measured number; measured number below the stated range.
By their numbers in this assay, from the lowest: compound 4; then compounds 1 and 2 (each within the scatter of the next); then compound 3.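

In this assay, the aromatic nitrogen of the five-membered aromatic ring does not need the five-membered non-aromatic ring of compound 1 for the effect: with butyl in its place, the step is a 2.7-fold lower number from compound 1 to compound 4 (0.44 log units; beyond the scatter), and it goes towards less compound needed. Among these compounds, compounds 1, 2 and 3 all carry a ring on this nitrogen, so this step is the first reading of an open chain there, and it shows that the series tolerates losing the ring, its double bond, and its hydrogen-bond donor and acceptors together. Nothing available explains why the number falls with this change, and the step alone assigns it to no single feature of the group that leaves.

Going by these compounds, it remains open whether the number depends on the length of the chain on this nitrogen, which a longer chain such as hexyl or a shorter one such as ethyl would test, and whether a butyl chain ending in an amine or a carboxylic acid would be accepted. Also open, on these data alone, is whether butyl gives a similar step when propyl replaces the allyl group on the other ring nitrogen.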